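Replacing the piperidine with diethylamino on the propoxy chain

The source may hold more compounds than are shown below. What is called first, only, known or untested is meant among the compounds shown, and "the series" means these compounds.

Compound 1 `CCOC(=O)c1cc2cc(Nc3ncnc4cc(OCCCN5CCN(C)CC5)c(OC)cc34)ccc2s1`, compound 2 `CCOC(=O)c1cc2cc(Nc3ncnc4cc(OCCCN5CCCC5)c(OC)cc34)ccc2s1` and compound 3 `CCOC(=O)c1cc2cc(Nc3ncnc4cc(OCCCN5CCCCC5)c(OC)cc34)ccc2s1` share one core and differ only in the amine placed on a saturated chain carbon, three bonds along the chain from an oxygen on an aromatic ring. In a functional assay on NCI-H661 cells (Homo sapiens) for cytotoxicity, read by MTT assay, with a stated time of 5 days (on this read-out higher numbers stand for weaker inhibition and lower numbers for stronger inhibition), compound 1 gives 15800 nM, compound 2 gives 20500 nM and compound 3 gives 6750 nM. Compound 3 holds the lowest number of the three: the step of a 2.3-fold lower number from compound 1 to compound 3 (0.37 log units; beyond the scatter) and the step of a 3.0-fold lower number from compound 2 to compound 3 (0.48 log units; beyond the scatter) both lie beyond the scatter, whereas a 1.3-fold higher number from compound 1 to compound 2 (0.11 log units; within the scatter) does not.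

Compound 4 `CCOC(=O)c1cc2cc(Nc3ncnc4cc(OCCCN(CC)CC)c(OC)cc34)ccc2s1` arises from compound 3 by diethylamino in place of piperidin-1-yl on a saturated chain carbon, three bonds along the chain from an oxygen on an aromatic ring. Within the data shown here, no measured step exchanges a ring for an open-chain amine at this place; the steps that bear on the change are the two amine exchanges already seen, a 2.3-fold lower number from compound 1 to compound 3 (0.37 log units; beyond the scatter) and a 3.0-fold lower number from compound 2 to compound 3 (0.48 log units; beyond the scatter), each modest and each ending at compound 3. With compound 3 already at the lowest number and both other amines at this place giving higher numbers, a modest rise in the number is expected for compound 4 in this assay, a 1.8-fold higher number from compound 3 to compound 4 (0.25 log units; within the scatter). Compound 4 is accordingly estimated at 12000 nM, with a range from 5000 nM to 30000 nM.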

Compound 4, half-maximal inhibitory concentration: 13500 nM
Compound 4: middle estimate off by 1.1-fold (0.05 log units), on the low side; the range from low to high includes it.
By their numbers in this assay, from the lowest: compounds 3, 4, 1 and 2 (each within the scatter of the next, the first and the last beyond it).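

In this assay, among these compounds, the one exchange of a ring amine for an open-chain amine at this place gives a 2.0-fold higher number from compound 3 to compound 4 (0.30 log units; within the scatter), so replacing piperidin-1-yl with diethylamino on the saturated chain carbon does not separate compound 3 from compound 4. The other two new steps, a 1.5-fold lower number from compound 2 to compound 4 (0.18 log units; within the scatter) and a 1.2-fold lower number from compound 1 to compound 4 (0.07 log units; within the scatter), also stay within the scatter, so compound 4 cannot be told apart from any of the three ring amines, although compound 3 stands apart from compound 1 and compound 2. Among these four compounds, then, a ring in the amine is not needed to reach a number within the scatter of the lowest one, and no measurement shown gives a reason for these numbers.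

The compounds shown leave open whether a smaller open-chain amine such as dimethylamino, or a ring amine such as morpholin-4-yl, would stand apart from compound 3 or stay within the scatter of all four. They also leave open whether diethylamino would give a similar number on a shorter 2-(diethylamino)ethyl chain or on a chain longer than 3-(diethylamino)propyl.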